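The source may report more compounds than this note shows. Statements on the series, on what has been measured and on what is new or still open speak of the compounds shown alone.

Measured compounds:
compound 1, `C=CCONC(=O)Cn1cc(C(=O)NCC(=O)N[C@@H](CC(C)C)C(=O)O)c2ccccc21`: > 128000 nM
compound 2, `CC(C)[C@H](NC(=O)CNC(=O)c1cn(CC(=O)NOCc2ccccc2)c2ccccc12)C(=O)O`: > 128000 nM

In a functional assay on RAW264.7 cells (Mus musculus) for inhibition, read by microscopy and resazurin assay, with a stated time of 72 h (on this read-out higher numbers stand for weaker inhibition and lower numbers for stronger inhibition), compound 1 gives only a limit of the assay, > 128000 nM. In this assay compound 2 likewise gives only a limit of the assay, > 128000 nM. Compound 2 thus stands where every value shown sits, at the limit of > 128000 nM in this assay, at which 2 of the 2 values shown sit. Compound 3, `CC(C)C[C@H](NC(=O)CNC(=O)c1cn(CC(=O)NOCc2ccccc2)c2ccccc12)C(=O)O`, differs from compound 2 by isobutyl in place of isopropyl on a saturated chain carbon bound to an amide-type nitrogen and a carbonyl carbon. With both known values being limits, the step is expected to be a number no higher from compound 2 to compound 3 (the limit leaves the size open), that is none beyond the scatter. Compound 3 is therefore estimated at 128000 nM, within 64000 nM to 400000 nM, most likely again reported only as a limit.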

Compound 3, half-maximal inhibitory concentration: > 128000 nM
Compound 3: only a limit was reported; the forecaster's own chance of this, stated with the estimate: 90%; the middle value sits exactly at the limit.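

In this assay compound 3 gives > 128000 nM, again only a limit of the assay. For the compounds shown here, no step to compound 3 from compound 1 or compound 2 can be read. The compounds shown leave open how strongly, if at all, any of them inhibits.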